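Methoxy to hydroxy: one change made twice in this series

The compounds below may be only part of what the source reports. "The series", "measured", "known", "first", "only" and "open" are said of these compounds alone.

Compounds measured in a functional assay on BV-2 cells (Mus musculus) for inhibition, read by Griess assay, with a stated time of 24 h; a lower number here means a stronger inhibitor, a higher number a weaker inhibitor:
Compound 1 `Oc1ccc(Br)cc1-c1ccn(-c2ccccc2)n1` gives > 200000 nM, which is a limit of the assay and not a number.
Compound 2 `COc1ccc(Br)cc1-c1ccn(-c2ccccc2)n1` gives > 200000 nM, again only a limit.
Compound 3 `C=CCc1ccc(OC)c(-c2ccn(CC=C)n2)c1` gives > 200000 nM, likewise a limit.

Compound 2 and compound 1 differ by hydrogen in place of methyl on an oxygen on an aromatic ring. The step that the two limits leave unreadable from compound 2 to compound 1 cannot be sized, since both values sit at the limit of > 200000 nM in this assay, at which 3 of the 3 values shown sit. Compound 3 and compound 2 differ in more than one place, and the difference between the two cores is not broken down here.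

Compound 4 `C=CCc1ccc(O)c(-c2ccn(CC=C)n2)c1` has not been measured in this assay. It differs from compound 3 by hydrogen in place of methyl on an oxygen on an aromatic ring, the same change as that made from compound 2 to compound 1, at the same kind of place. Compound 4 is expected to return a limit rather than a number, with an estimated middle of 300000 nM and a range from 100000 nM to 1000000 nM. The step from compound 3 is estimated as a step that the limit leaves unreadable from compound 3 to compound 4, an expectation that rests on the unreadable step that the two limits leave unreadable from compound 2 to compound 1 and on the fact that (the limit of > 200000 nM in this assay, at which 3 of the 3 values shown sit).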

Compound 4, half-maximal inhibitory concentration: 1200 nM
Compound 4: the middle estimate sits 250-fold (2.40 log units) above what was measured, outside the stated range (below it).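

In this assay methoxy to hydroxy gives an at least 160-fold lower number from compound 3 to compound 4 (2.22 log units; beyond the scatter) on that core, a large step beyond the scatter. On the core of compound 2 the same change cannot be read, as compound 2 and compound 1 both stand at a limit of the assay and not at a number: the limit of > 200000 nM in this assay, at which 3 of the 4 values shown sit. The change is thus sized on one core only, and this neither shows that it carries from one core to the other nor shows that it fails to, so a hydroxy on the core of compound 2 cannot be ranked against the one on the core of compound 3.

The compounds shown leave open which of the differences between the two cores separates compound 4 from compound 1, as those cores differ in more than one place. Also open, from the compounds shown here alone, is how an amine or a carboxylic acid in place of the hydroxy would read on the core of compound 4.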